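Dropping the bromophenyl arm from a tetralin-fused enol lactone

The source may report more compounds than this note shows. Statements on the series, on what has been measured and on what is new or still open speak of the compounds shown alone.

Two compounds sharing a tetralin core fused to an enol lactone have been examined in a functional assay on SK-OV-3 cells (Homo sapiens) for inhibition, with a stated time of 72 h; a higher number here means a weaker inhibitor, a lower number a stronger inhibitor. Compound 1 `COc1ccc(C2Cc3ccccc3C(C3=C(O)OCCC3=O)C2)cc1` gives only a limit in this assay, at > 10000 nM. Going by the values given here, compound 2 `CC1(c2ccccc2)CC(=O)C(C2CC(c3ccc(-c4ccc(Br)cc4)cc3)Cc3ccccc32)=C(O)O1` gives 1800 nM in this assay, which is the only number obtained. The other entry, that of compound 1, is a limit (the limit of > 10000 nM in this assay, at which 1 of the 2 values shown sits). Among the compounds with values here, compound 2 thus stands alone as the one compound with a measured inhibitory concentration. Compound 3 `COc1ccc(C2Cc3ccccc3C(C3=C(O)OC(C)(c4ccccc4)CC3=O)C2)cc1` has not yet been measured. It differs from compound 2 by methoxy in place of 4-bromophenyl on an aromatic carbon of the six-membered aromatic ring, para to a large group, while keeping the methyl and phenyl substituents on the lactone ring. Within the data shown here, with no pair of measured compounds differing in one place, the size of this step is uncertain, but compound 3 is expected to be the weaker inhibitor, with a step of a 3.3-fold higher number from compound 2 to compound 3 (0.52 log units; beyond the scatter) in this assay. Compound 3 is estimated at 6000 nM in this assay, with a range from 2000 nM to 20000 nM, and a real chance that only a limit is recorded.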

Compound 3, half-maximal inhibitory concentration: > 10000 nM
Compound 3: a limit, no number; the forecaster's own chance of this, stated with the estimate: 40%; middle value at least 1.6-fold (0.22 log units) away from the limit.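

Going by these compounds alone, this is the first step across a single change, and it shows that this aromatic carbon, para to a large group, is not indifferent to what it carries: methoxy in place of 4-bromophenyl gives an at least 5.5-fold higher number from compound 2 to compound 3 (0.74 log units; beyond the scatter) in this assay. The methyl and phenyl substituents on the lactone ring stay in place across this change, so in compound 3 they do not by themselves preserve a measurable inhibitory concentration. Compound 3 gives only a limit, so the true size of the step stays unknown, and it shares that limit with compound 1: the limit of > 10000 nM in this assay, at which 2 of the 3 values shown sit.

The compounds shown cannot separate the contribution of the bromine from that of the added aromatic ring. Going by these compounds, whether a 4-chlorophenyl, a 4-cyanophenyl or an amine-bearing group at this carbon would keep or improve the value of compound 2 remains open.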